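Swapping a nonyl chain for a cyclohexylcarbamoyl group

A few compounds are considered here, and "the series" means these few. Any claim that something is new, unique, unknown or untested is made for them only; others in the source may bear on it.

Of the compounds shown here, three built on one shared core have been tested in a functional assay on THP-1 cells (Homo sapiens) for cytotoxicity, read by MTT assay, with a stated time of 24 h; a lower number here means a stronger inhibitor, a higher number a weaker inhibitor. Compound 1 `CCCCCCCCCCn1cc(Cn2nc(N)c3c(C(F)(F)F)cc(-c4ccccc4)nc32)nn1` carries a nonyl group on a saturated chain carbon bound to an aromatic nitrogen, and in this assay compound 1 gives 48.7 ug/mL. Compound 2 `Nc1nn(Cc2cn(CC(=O)Nc3cccc(Cl)c3)nn2)c2nc(-c3ccccc3)cc(C(F)(F)F)c12` gives 37 ug/mL, and compound 3 `Nc1nn(Cc2cn(CC(=O)Nc3ccc(F)cc3Br)nn2)c2nc(-c3ccccc3)cc(C(F)(F)F)c12` gives 65.6 ug/mL. Compound 1 stands second highest of these three numbers; its nearest neighbour is compound 2 and its furthest is compound 3, with both gaps within the scatter. Between the other two, a 1.8-fold higher number from compound 2 to compound 3 (0.25 log units; within the scatter).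

Compound 4 `Nc1nn(Cc2cn(CC(=O)NC3CCCCC3)nn2)c2nc(-c3ccccc3)cc(C(F)(F)F)c12` has not yet been measured. It differs from compound 1 in one place: cyclohexylcarbamoyl in place of nonyl on a saturated chain carbon bound to an aromatic nitrogen. The measured steps that bear on this change are the two that also replace the nonyl group on that same carbon with a carbamoyl group: a 1.3-fold lower number from compound 1 to compound 2 (0.12 log units; within the scatter) and a 1.3-fold higher number from compound 1 to compound 3 (0.13 log units; within the scatter). Neither of those replacements moved the number beyond the scatter, so no step beyond the scatter is expected for a cyclohexylcarbamoyl group either. On that basis compound 4 is expected to give about 50 ug/mL, somewhere between 25 ug/mL and 100 ug/mL. The step this estimate implies is expected to be a 1.0-fold higher number from compound 1 to compound 4 (0.01 log units; within the scatter).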

Compound 4, half-maximal inhibitory concentration: 64.8 ug/mL
Compound 4: middle estimate off by 1.3-fold (0.11 log units), on the low side; the range from low to high includes it.
By their numbers in this assay, from the lowest: compounds 2, 1, 4 and 3 (each within the scatter of the next).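

In this assay, the change from nonyl to cyclohexylcarbamoyl gives a 1.3-fold higher number from compound 1 to compound 4 (0.12 log units; within the scatter), so this third carbamoyl group on the saturated chain carbon, and the first shown with no aromatic ring on its amide nitrogen, also stays within the scatter of the nonyl compound. On the amide nitrogen itself, cyclohexyl in place of 2-bromo-4-fluorophenyl gives a 1.0-fold lower number from compound 3 to compound 4 (0.01 log units; within the scatter), and cyclohexyl in place of 3-chlorophenyl gives a 1.8-fold higher number from compound 2 to compound 4 (0.24 log units; within the scatter), so across these four compounds neither the exchange of the chain for a carbamoyl group nor the exchange of an aromatic ring for a saturated one separates the numbers, and none of the four goes against this. No measurement is available that would explain this flat picture.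

Still open, as far as these compounds go, is whether any group on this carbon can move the number beyond the scatter, for example a carboxylic acid, a primary amine or a much shorter chain such as methyl. The compounds shown also leave open whether the same flat picture would hold with the trifluoromethyl or phenyl group of the shared core replaced, since both stay the same throughout.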